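Swapping fluorine for methyl on a cyclopropyl amide

The source may report more compounds than this note shows. Statements on the series, on what has been measured and on what is new or still open speak of the compounds shown alone.

Compound 3 `O=C([C@H]1C[C@@H]1F)N1CC2CC(C1)N2` gives 5.4 nM in an assay on SH-EP1 cells for displacement of a labelled ligand from Neuronal acetylcholine receptor; alpha4/beta2 (Homo sapiens), read by scintillation counting (a higher number here means a weaker inhibitor, a lower number a stronger inhibitor), the lowest of the three numbers measured. Compound 1 `CCCC(=O)N1CC2CC(C1)N2` gives 14 nM in this assay, and compound 2 `CC(C)C(=O)N1CC2CC(C1)N2` gives 130 nM. The step of a 2.6-fold lower number from compound 1 to compound 3 (0.41 log units; beyond the scatter) and the step of a 24-fold lower number from compound 2 to compound 3 (1.38 log units; beyond the scatter) both moved toward stronger binding when a 2-fluorocyclopropyl group replaced an open chain on the carbonyl carbon, while the step of a 9.3-fold higher number from compound 1 to compound 2 (0.97 log units; beyond the scatter) showed that branching that chain weakened binding.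

Compound 4 `C[C@@H]1C[C@H]1C(=O)N1CC2CC(C1)N2` keeps the ring and exchanges one atom on it: 2-methylcyclopropyl in place of 2-fluorocyclopropyl on a carbonyl carbon. Among the compounds with values here, none of the measured steps changes one substituent on the cyclopropane ring for another, so this exchange has no direct precedent here. The measured steps show that the three-membered ring itself, rather than the fluorine, accompanied the gain in compound 3, because the step of a 24-fold lower number from compound 2 to compound 3 (1.38 log units; beyond the scatter) was large even though compound 2 and compound 3 differ only at that group. Compound 4 is therefore expected to stay close to compound 3, with a small step of a 1.5-fold higher number from compound 3 to compound 4 (0.17 log units; within the scatter) toward a slightly higher number that may not exceed the scatter. The estimate for compound 4 in this assay is 8 nM, within a range from 3 nM to 25 nM.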

Compound 4, inhibition constant: 1 nM
Compound 4: the middle estimate sits 8.0-fold (0.90 log units) above what was measured, outside the stated range (below it).
By their numbers in this assay, from the lowest: compound 4; then compound 3; then compound 1; then compound 2.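

In this assay, putting 2-methylcyclopropyl in place of 2-fluorocyclopropyl on the carbonyl carbon gives a 5.4-fold lower number from compound 3 to compound 4 (0.73 log units; beyond the scatter), so what the ring carries matters and the three-membered ring alone does not set the value, even though both groups have the same count of heavy atoms. The gain over the open chains also grows with this group, with a 14-fold lower number from compound 1 to compound 4 (1.15 log units; beyond the scatter) for propyl replaced and a 130-fold lower number from compound 2 to compound 4 (2.11 log units; beyond the scatter) for isopropyl replaced, which leaves compound 4 as the strongest binder of the four, with each of its steps beyond the scatter. Nothing available here explains why methyl on the ring gives a lower number than fluorine.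

Still open, going by these compounds, is how the ring behaves with no substituent at all, as a plain cyclopropyl, or with a larger one such as ethyl or trifluoromethyl. Also open is how the other stereoisomers of 2-methylcyclopropyl would compare, since only one defined arrangement of its two stereocentres appears among these compounds.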